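Dimethylamino versus Cyclopropylamino on a Shared Core

A few compounds are considered here, and "the series" means these few. Any claim that something is new, unique, unknown or untested is made for them only; others in the source may bear on it.

Of the compounds shown here, three have been measured in a functional assay on SW480 cells (Homo sapiens) for inhibition, read by luminescence and resazurin assay, with a stated time of 3 days; on this read-out higher numbers stand for weaker inhibition and lower numbers for stronger inhibition. Compound 1 `CNc1nc(NCc2ccc(C(=O)Nc3ccc(F)cc3)cc2)c2ccccc2n1` gives 4100 nM in this assay, compound 2 `CN(C)c1nc(NCc2ccc(NC(=O)c3ccncc3)cc2)c2ccccc2n1` gives 11000 nM, and compound 3 `O=C(Nc1ccc(F)cc1)c1ccc(CNc2nc(NC3CC3)nc3ccccc23)cc1` gives 2600 nM. The gap from compound 3 to compound 1 is within the scatter, while compound 2 stands beyond it. The only single-point step among these is a 1.6-fold lower number from compound 1 to compound 3 (0.20 log units; within the scatter), so swapping one small group on that nitrogen left the number essentially unchanged.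

Compound 4 `CN(C)c1nc(NCc2ccc(C(=O)Nc3ccc(F)cc3)cc2)c2ccccc2n1` differs from compound 3 in one place: dimethylamino in place of cyclopropylamino on an aromatic carbon, the amine on the shared core becoming dimethylamino. Compound 2 also carries dimethylamino, but it differs from compound 3 in more than one place, so its value cannot be read as a step. Among the compounds with values here, the one relevant step was within the scatter, so the change from compound 3 to compound 4 is expected to be small, with no direction beyond the scatter. Compound 4 is therefore estimated at 4000 nM, within 1500 nM to 11000 nM, a step of a 1.5-fold higher number from compound 3 to compound 4 (0.19 log units; within the scatter).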

Compound 4, half-maximal inhibitory concentration: 2600 nM
Compound 4: middle estimate off by 1.5-fold (0.19 log units), on the high side; the range from low to high includes it.
By their numbers in this assay, from the lowest: compounds 3, 4 and 1 (each within the scatter of the next); then compound 2.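

The step of no change at the digits printed from compound 3 to compound 4 (within the scatter) shows that, on the aromatic carbon between two ring nitrogen atoms, dimethylamino can stand in place of cyclopropylamino, even though the three-membered ring and the hydrogen-bond donor counted on that group are gone. The step of a 1.6-fold lower number from compound 1 to compound 4 (0.20 log units; within the scatter) adds methyl in place of hydrogen on the same nitrogen, so compounds 1, 3 and 4 do not separate at this position. With dimethylamino held constant, the step of a 4.2-fold lower number from compound 2 to compound 4 (0.63 log units; beyond the scatter) goes beyond the scatter when (4-fluorophenyl)carbamoyl replaces ((pyridin-4-yl)carbonyl)amino, so among these compounds the number moved at that other place and not at the amine.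

On these data alone, whether a morpholine ring or a longer chain such as hexylamino at the amine position would also leave the number unmoved stays open. Nothing available explains why these amine groups match or why the swap at the other place counts.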